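Chloro for methoxy on a cytotoxicity readout

The compounds below may be only part of what the source reports. "The series", "measured", "known", "first", "only" and "open" are said of these compounds alone.

Measured compounds:
compound 1 `COc1ccc(-c2cc(-c3ccc(C4NC(=O)c5ccccc5N4)cc3)nc(N)n2)cc1`: 124000 nM
compound 2 `CC1(c2ccc(NC(c3ccc(Br)cc3)c3nnnn3C3CCCCC3)cc2)NC(=O)c2ccccc2N1`: > 400000 nM

Compound 1 `COc1ccc(-c2cc(-c3ccc(C4NC(=O)c5ccccc5N4)cc3)nc(N)n2)cc1` was tested in an ADME assay on Vero cells (Chlorocebus sabaeus) for cytotoxicity, read by MTT assay, with a stated time of 72 h (a higher number here means that more compound is tolerated, a lower number that less compound is tolerated), where compound 1 gives 124000 nM, the only plain number shown. Compound 2 `CC1(c2ccc(NC(c3ccc(Br)cc3)c3nnnn3C3CCCCC3)cc2)NC(=O)c2ccccc2N1` is reported in this assay only as a limit, and compound 2 gives > 400000 nM. The limit in this assay is the limit of > 400000 nM in this assay, at which 1 of the 2 values shown sits, so compound 1 cannot be ranked against it beyond saying that one value is a number and the other is not.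

Compound 3 `Nc1nc(-c2ccc(Cl)cc2)cc(-c2ccc(C3NC(=O)c4ccccc4N3)cc2)n1` differs from compound 1 in one place: chloro in place of methoxy on an aromatic carbon. Going by the values given here, no measured pair shows this change, so the expected step in this assay is small, within the scatter, and of no settled direction. For compound 3 the estimate is 100000 nM, between 40000 nM and 300000 nM, which for compound 3 means an expected step of a 1.2-fold lower number from compound 1 to compound 3 (0.09 log units; within the scatter).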

Compound 3, half-maximal cytotoxic concentration: 323000 nM
Beside the measured number, compound 3's estimate is 3.2-fold (0.51 log units) below it; measured number above the stated range.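

Going by these compounds alone, at this position, on a six-membered aromatic ring of carbon only and para to a large group, the change from methoxy to chloro is the first one in this assay that can be read as a step: a 2.6-fold higher number from compound 1 to compound 3 (0.42 log units; beyond the scatter). Within the data shown here, the earlier compounds offered no pair differing in one place, so this is the first sign that the group here matters for how much compound the cells tolerate, and with chloro in place more compound is tolerated. Nothing measured here accounts for the step.

As far as these compounds go, this rests on a single pair, so it remains open whether other groups at this position, such as an amine, a carboxylic acid or a longer alkoxy chain, would move the number the same way. From the compounds shown here alone, it also remains open whether the same change would give a similar step on a different core.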